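The source may report more compounds than this note shows. Statements on the series, on what has been measured and on what is new or still open speak of the compounds shown alone.

Compound 2 `O=C(Nc1cccc(-c2nc3ccccc3s2)c1)c1ccc(Cl)nc1Cl` carries a 2,6-dichloropyridin-3-yl group on the carbonyl carbon of its amide. In an ADME assay on HEK293 cells (Homo sapiens) for inhibition, with a stated time of 72 h (on this read-out lower numbers stand for an effect already at smaller amounts and higher numbers for an effect only at larger amounts of compound), compound 2 gives > 25000 nM, which is a limit of the assay and not a measured number. Its neighbour compound 1 `CC(C)(CCl)C(=O)Nc1cccc(-c2nc3ccccc3s2)c1`, with a 1-(chloromethyl)-1-methylethyl group in that place, also gives only a limit in this assay, > 25000 nM. The step that the two limits leave unreadable from compound 1 to compound 2 therefore cannot be read in size or direction: both values sit at the limit of > 25000 nM in this assay, at which 2 of the 2 values shown sit. So compound 2 stands at the edge of what this assay can report, with no measured effect up to the highest amount tested.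

Compound 3 `O=C(Nc1cccc(-c2nc3ccccc3s2)c1)c1ccnc(Cl)c1` differs from compound 2 only in the group on that carbonyl carbon: 2-chloropyridin-4-yl in place of 2,6-dichloropyridin-3-yl on a carbonyl carbon. No measured step bears on this change, since the single step shown is unreadable. With nothing pointing away from the limit, compound 3 is expected to stay close to it, meaning a step that the limit leaves unreadable from compound 2 to compound 3 in this assay. The estimate for compound 3 is thus 30000 nM, with a range from 8000 nM to 100000 nM.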

Compound 3, half-maximal effective concentration: > 25000 nM
Compound 3: a limit, no number; the forecaster's own chance of this, stated with the estimate: 65%; the middle value is on the limit's open side.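

Compound 3 also ends at a limit of the assay and not at a number, so neither its step from compound 1 nor its step from compound 2 can be read in size or direction in this assay: the limit of > 25000 nM in this assay, at which 3 of the 3 values shown sit.

The compounds shown leave open whether any group on the carbonyl carbon of this amide gives a measurable effect in this assay.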